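The compounds below may be only part of what the source reports. "The series", "measured", "known", "first", "only" and "open" are said of these compounds alone.

Working notes on the series. The shared core of compound 1 `Cc1cc(O)c(C(=O)/C=C/c2ccccc2)c(-c2ccc(Br)cc2)c1C(=O)/C=C/c1ccccc1` carries a bromophenyl group and two unsubstituted cinnamoyl arms; in a functional assay on HeLa cells (Homo sapiens) for cytotoxicity, read by MTT assay, with a stated time of 24 h (on this read-out higher numbers stand for weaker inhibition and lower numbers for stronger inhibition), compound 1 gives 30000 nM, a weak effect. Within the data shown here, compound 2 `Cc1cc(O)c(C(=O)/C=C/c2ccc(Br)cc2)c(-c2ccc(OCc3ccccc3)cc2)c1C(=O)/C=C/c1ccc(Br)cc1` moves the bromine atoms onto both cinnamoyl arms and places a benzyloxy group on the pendant phenyl ring; in this assay compound 2 gives "not active" (no number reported), with no number, so compound 2 stands without a numerical value and no step between measured compounds can be drawn. Compound 3 `Cc1cc(O)c(C(=O)/C=C/c2ccc(Br)cc2)c(-c2ccccc2)c1C(=O)/C=C/c1ccc(Br)cc1` is the next point: hydrogen in place of benzyloxy on an aromatic carbon. With compound 2 reported as not active and compound 1 only weakly active in this assay, no shift of meaningful size in any direction is anticipated for this step; any change in this assay would likely remain within scatter or stay beyond the measurable range. In this assay compound 3 is expected to give about 40000 nM, estimated within 15000 nM to 100000 nM.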

Compound 3, half-maximal inhibitory concentration: 33500 nM
Compound 3: middle estimate off by 1.2-fold (0.08 log units), on the high side; the range from low to high includes it.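

Among these compounds, compound 2 has no number in this assay, so no step from compound 2 to compound 3 can be read. The compounds shown leave open how far benzyloxy versus hydrogen at this place shifts the read-out. No supporting evidence bears on this result.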